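Thiophene for furan on two nucleoside cores

The source may hold more compounds than are shown below. What is called first, only, known or untested is meant among the compounds shown, and "the series" means these compounds.

Three compounds have been run in a functional assay on CCRF-CEM cells (Homo sapiens), read by MTT assay, with a stated time of 72 h; a lower number here means a stronger inhibitor, a higher number a weaker inhibitor. Compound 3 `Cc1nc(N)c2c(-c3ccoc3)cn([C@@H]3O[C@H](CO)[C@@H](O)[C@H]3O)c2n1` returns only a limit in this assay, > 100000 nM. Compound 1 `Cc1nc(N)c2c(-c3cccs3)cn([C@@H]3O[C@H](CO)[C@@H](O)[C@H]3O)c2n1` likewise returns only a limit in this assay, > 20000 nM. The change between the two is thiophen-2-yl in place of furan-3-yl on an aromatic carbon, and the step that the two limits leave unreadable from compound 3 to compound 1 cannot be read because the limit of > 100000 nM in this assay, at which 1 of the 3 values shown sits, and the limit of > 20000 nM in this assay, at which 1 of the 3 values shown sits, mark both of its ends. Compound 2 `CSc1ncnc2c1c(-c1ccoc1)cn2[C@@H]1O[C@H](CO)[C@@H](O)[C@H]1O` carries a different core; the difference between its core and that of compound 3 is not broken down here. In this assay, within the data shown here, compound 2 gives 14200 nM, the only number among the three values recorded so far.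

Compound 4 `CSc1ncnc2c1c(-c1cccs1)cn2[C@@H]1O[C@H](CO)[C@@H](O)[C@H]1O` has not yet been measured. It differs from compound 2 by thiophen-2-yl in place of furan-3-yl on an aromatic carbon, the same kind of change as that from compound 3 to compound 1, and the place is described in the same words in both cases. That earlier step gives no readable size, so the expectation for compound 4 rests on compound 2 alone: its value 14200 nM serves as the anchor, and the step of a 1.0-fold lower number from compound 2 to compound 4 (0.01 log units; within the scatter) is expected to be small, with wide uncertainty in either direction. Compound 4 is accordingly estimated at 14000 nM in this assay, with a range from 5000 nM to 40000 nM, and a fair chance that only a limit is returned.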

Compound 4, half-maximal inhibitory concentration: > 20000 nM
Compound 4 was reported as a limit; the forecaster's own chance of this, stated with the estimate: 35%; at least 1.4-fold (0.15 log units) between middle value and limit.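

In this assay, thiophen-2-yl in place of furan-3-yl on an aromatic carbon of the core of compound 2 gives an at least 1.4-fold higher number from compound 2 to compound 4 (0.14 log units; that floor lies within the scatter), so on this core the change brings no gain in strength that the assay can show, while the floor of the step does not establish a real loss. As far as these compounds go, compound 4 returns only a limit, > 20000 nM, so the true size of the step stays unknown and could be anywhere from negligible to large. The same change on the core of compound 3 cannot be read, since both of its ends are limits, so these data do not show whether the change behaves alike on the two cores and give no transferable size for it.

Among these compounds, compound 2, at 14200 nM, remains the only number in this assay, which leaves the series with no measured step of known size and no reading of how far activity can move at this aromatic carbon. Also open, from the compounds shown here alone, is whether a group of a different kind at that carbon, such as an amine, a carboxylic acid or a longer chain, would return a number on either core rather than a limit.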